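The compounds below may be only part of what the source reports. "The series", "measured", "known", "first", "only" and "open" are said of these compounds alone.

Working notes on the series. Among the compounds with values here, compound 3 `COc1ccc(S(=O)(=O)Nc2ccc3oc(-c4ccc(NC(=O)c5ccc(Cl)s5)cc4)nc3c2)cc1` holds the lowest number of the three measured so far: in a functional assay on HCT-116 cells (Homo sapiens) for cytotoxicity, read by resazurin assay, with a stated time of 48 h (on this read-out lower numbers stand for an effect already at smaller amounts and higher numbers for an effect only at larger amounts of compound), compound 3 gives 5400 nM. Compound 1 `COc1ccc(S(=O)(=O)Nc2ccc3oc(-c4ccc(NS(=O)(=O)c5cc(F)ccc5OC)cc4)nc3c2)cc1` gives 15000 nM, and compound 2 `O=S(=O)(Nc1ccc(-c2nc3cc(NS(=O)(=O)c4ccccc4)ccc3o2)cc1)c1ccccc1` gives 13000 nM. Within the data shown here, the only measured step between compounds differing in one place is a 2.8-fold lower number from compound 1 to compound 3 (0.44 log units; beyond the scatter), a swap of the whole group on the aromatic nitrogen, which is what sets compound 3 apart from the other two.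

Compound 4 `COc1ccc(S(=O)(=O)Nc2ccc3oc(-c4ccc(NC(=O)c5cccc(C)c5[N+](=O)[O-])cc4)nc3c2)cc1` keeps the amide carbonyl of compound 3 and differs from it only at (3-methyl-2-nitrophenyl in place of 5-chlorothiophen-2-yl on a carbonyl carbon). Among the measured compounds shown here, no measured step changes the group on that carbonyl carbon. The step from compound 1 to compound 3 brought in the (5-chlorothiophen-2-yl)carbonyl in place of a sulfonyl-bearing group and so does not bear directly on a swap of one aryl for another on the carbonyl. With nothing closer to go on, no step beyond the scatter is expected in either direction. The expected step is a 1.1-fold higher number from compound 3 to compound 4 (0.05 log units; within the scatter). Compound 4 is therefore estimated at about 6000 nM, with a range of 2500 nM to 15000 nM.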

Compound 4, half-maximal effective concentration: 4400 nM
Beside the measured number, compound 4's estimate is 1.4-fold (0.13 log units) above it, within the range that was stated.
By their numbers in this assay, from the lowest: compounds 4 and 3 (each within the scatter of the next); then compounds 2 and 1 (each within the scatter of the next).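

In this assay, the change on the carbonyl carbon gives a 1.2-fold lower number from compound 3 to compound 4 (0.09 log units; within the scatter), so a 3-methyl-2-nitrophenyl group serves in place of 5-chlorothiophen-2-yl without a step beyond the scatter, despite the change of ring type and the loss of sulfur and chlorine. The other new step, a 3.4-fold lower number from compound 1 to compound 4 (0.53 log units; beyond the scatter), gives a second aryl amide that stands apart from the sulfonyl-bearing compound 1, as a 2.8-fold lower number from compound 1 to compound 3 (0.44 log units; beyond the scatter) did for the first; among these compounds, none goes against this. Nothing measured here accounts for the two aryl groups reading alike.

Open, going by these compounds, is whether an aromatic ring on the carbonyl carbon is needed at all, which a morpholine or a short alkyl chain there would test. Also open, on these data alone, is whether the carbonyl itself counts, or whether a sulfonyl carrying 5-chlorothiophen-2-yl would read the same.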